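Working notes: from compound 1 to compound 3

The source may report more compounds than this note shows. Statements on the series, on what has been measured and on what is new or still open speak of the compounds shown alone.

Within the data shown here, in a physicochemical assay for lipophilicity (on this read-out higher numbers stand for higher lipophilicity and lower numbers for lower lipophilicity), compound 1 (`CCOC(=O)C1=C(C)NC(=S)NC1c1cn(C(=O)CNc2ccc([N+](=O)[O-])c(Cl)c2)c2ccccc12`) reads 3.4 and stands as the higher of the two numbers so far. Compound 2 (`CCOC(=O)C1=C(C)NC(=O)NC1c1cn(C(=O)CNc2ccc([N+](=O)[O-])cc2C)c2ccccc12`) reads 1.94 on the same scale, a gap well beyond the usual scatter. These two compounds differ in more than one place, so their gap cannot be assigned to any single change. Compound 3 (`CCOC(=O)C1=C(C)NC(=S)NC1c1cn(C(=O)CNc2ccc(Cl)cc2)c2ccccc12`) keeps the core of compound 1 and changes one group: 4-chlorophenyl in place of 3-chloro-4-nitrophenyl on an amine nitrogen with 4-chlorophenyl in place of 3-chloro-4-nitrophenyl on an amine nitrogen. Among the measured compounds shown here, no measured pair shows this change alone, so the expectation starts from compound 1 at 3.4 and carries wide margins. The expected a number 0.20 log units higher from compound 1 to compound 3 (within the scatter) in this assay is a small rise, possibly no larger than the scatter. For compound 3 the estimated value is 3.6 in an expected range running from 3.1 to 4.1 on this scale.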

Compound 3, partition coefficient: 3.44
For compound 3 the middle estimate is 0.16 log units above the measured one; the range from low to high includes it.
By their numbers in this assay, from the lowest: compound 2; then compounds 1 and 3 (each within the scatter of the next).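

Among these compounds, the step on the amine nitrogen, 4-chlorophenyl in place of 3-chloro-4-nitrophenyl, reads a number 0.04 log units higher from compound 1 to compound 3 (within the scatter) in this assay and is the first comparison that differs in one place only. Although 4-chlorophenyl is the smaller group by heavy atoms and has no hydrogen-bond acceptors, compound 1 and compound 3 cannot be told apart on this read-out, so this exchange leaves the reading unresolved from the scatter for this pair. No measurement in hand accounts for that outcome.

This single pair does not establish a rule for the position, and compound 2, at 1.94, still differs from compound 1 and from compound 3 in more than one place, so its gap to them remains unassigned to any one change. Also open, going by these compounds, is how the reading would respond to a phenyl group carrying an amine or a carboxylic acid on this amine nitrogen, with the rest of the core of compound 1 kept in place.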